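The source may report more compounds than this note shows. Statements on the series, on what has been measured and on what is new or still open speak of the compounds shown alone.

Compound 1 `CC[C@@H]1C(=O)N(C)c2cnc(Nc3ccc(S(=O)(=O)NCCCO)cc3)nc2N1C1CCCC1` gives 8.16 nM in an assay for inhibition of serine/threonine-protein kinase PLK2 (Homo sapiens), read by FRET and Z'-LYTE, with a stated time of 1 h; on this read-out lower numbers stand for stronger inhibition and higher numbers for weaker inhibition. Compound 2 `CC[C@@H]1C(=O)N(C)c2cnc(Nc3ccc(S(N)(=O)=O)cc3)nc2N1C1CCCC1` gives 10.2 nM. Compound 3 `CCC1C(=O)N(C)c2cnc(Nc3ccc(S(N)(=O)=O)cc3)nc2N1c1ccn(C)n1` gives 121 nM.

Compound 1 and compound 2 share one core and differ only by 3-hydroxypropyl in place of hydrogen on a sulfonamide nitrogen; this change gave a 1.3-fold lower number from compound 2 to compound 1 (0.10 log units; within the scatter), so the two numbers cannot be told apart. Compound 3 is built on a different core; how the two cores differ is not broken down here, but compound 3 stands at the highest of the three numbers, beyond the scatter from both others. Compound 4 `CCC1C(=O)N(C)c2cnc(Nc3ccc(S(=O)(=O)NCCCO)cc3)nc2N1c1ccn(C)n1` has not yet been measured. It differs from compound 3 by 3-hydroxypropyl in place of hydrogen on a sulfonamide nitrogen, the same change, at the same place, as between compound 2 and compound 1. That earlier change gave a 1.3-fold lower number from compound 2 to compound 1 (0.10 log units; within the scatter). A similarly small step is expected again, a 1.2-fold lower number from compound 3 to compound 4 (0.08 log units; within the scatter), although it now sits on the other core, where the change has not been tested. Compound 4 is expected to give about 100 nM, between 50 nM and 200 nM.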

Compound 4, half-maximal inhibitory concentration: 192 nM
The estimate for compound 4 lay 1.9-fold (0.28 log units) below the measured number; low and high end bracket the measured number.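

On the second core, 3-hydroxypropyl in place of hydrogen on a sulfonamide nitrogen gave a 1.6-fold higher number from compound 3 to compound 4 (0.20 log units; within the scatter) in this assay. Set beside the step on the first core, the two steps cannot be told apart, so on both cores this change leaves the number within the scatter: the same change on two cores in this assay, a 1.3-fold lower number (0.10 log units; within the scatter) from compound 2 to compound 1 and a 1.6-fold higher number (0.20 log units; within the scatter) from compound 3 to compound 4, 2.0-fold (0.30 log units) apart, within the scatter of two such steps. Within the data shown here, this rests on only two pairs of compounds, so it does not show that the change would behave the same way on any other core, or that the two steps truly point in opposite directions.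

Still open, on these data alone, is how a longer chain on that nitrogen would read on either core. The same goes for a chain ending in an amine or a carboxylic acid instead of the hydroxyl.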